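A Methylamino Group Replaces the Nitrile on the Shared Core

A few compounds are considered here, and "the series" means these few. Any claim that something is new, unique, unknown or untested is made for them only; others in the source may bear on it.

Three measured compounds share one core and differ only in the group on a single aromatic carbon. Compound 1 `CC(C)c1ncncc1-c1nc2cc(F)c(F)cc2n1C1CC1` carries an isopropyl group there, and in an assay on cells for inhibition of cytochrome P450 11B2, mitochondrial (Homo sapiens), read by HPLC, with a stated time of 90 min (on this read-out higher numbers stand for weaker inhibition and lower numbers for stronger inhibition), compound 1 gives 5 nM. Compound 2 `Fc1cc2nc(-c3cncnc3C3CC3)n(C3CC3)c2cc1F` carries a cyclopropyl group, and in this assay compound 2 gives 172 nM; the step of a 34-fold higher number from compound 1 to compound 2 (1.54 log units; beyond the scatter) shows how strongly this position responds. Compound 3 `N#Cc1ncncc1-c1nc2cc(F)c(F)cc2n1C1CC1` carries a cyano group, and in this assay compound 3 gives 13 nM, the second highest of the three numbers, with a 2.6-fold higher number from compound 1 to compound 3 (0.41 log units; beyond the scatter) and a 13-fold lower number from compound 2 to compound 3 (1.12 log units; beyond the scatter).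

Compound 4 `CNc1ncncc1-c1nc2cc(F)c(F)cc2n1C1CC1` is not yet measured. The change is methylamino in place of cyano on an aromatic carbon. For the measured compounds named here, no measured step exchanges a cyano for a methylamino group, so the expectation rests only on the spread among compounds 1, 2 and 3. Because a 34-fold higher number from compound 1 to compound 2 (1.54 log units; beyond the scatter) and a 13-fold lower number from compound 2 to compound 3 (1.12 log units; beyond the scatter) are large, a sizeable move in either direction is plausible, while the modest 2.6-fold higher number from compound 1 to compound 3 (0.41 log units; beyond the scatter) shows that small groups can keep the number low. Compound 4 is therefore expected to show a step of a 2.7-fold higher number from compound 3 to compound 4 (0.43 log units; beyond the scatter), toward a somewhat higher number. The estimate for compound 4 in this assay is 35 nM, with a range from 8 nM to 250 nM.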

Compound 4, half-maximal inhibitory concentration: < 2 nM
Compound 4 gave a limit, no number; the forecaster's own chance of this, stated with the estimate: 3%; at least 17-fold (1.24 log units) between middle value and limit.
By their numbers in this assay, from the lowest: compound 1; then compound 3; then compound 2. At a limit, below all of these: compound 4.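

Compound 4 gives a limit and not a number: the limit of < 2 nM in this assay, at which 1 of the 4 values shown sits.

Exchanging the nitrile for methylamino gives an at least 6.5-fold lower number from compound 3 to compound 4 (0.81 log units; beyond the scatter), even though the two groups have the same count of heavy atoms and methylamino brings a hydrogen-bond donor that cyano lacks. The new group also passes the isopropyl group, the lowest so far, with an at least 2.5-fold lower number from compound 1 to compound 4 (0.39 log units; beyond the scatter), and it stretches the spread at this single aromatic carbon to an at least 86-fold lower number from compound 2 to compound 4 (1.93 log units; beyond the scatter).

The compounds shown cannot tell whether the hydrogen-bond donor is what matters, and how far the true value of compound 4 lies past its limit stays unknown. A plain amine, a dimethylamino group or a methoxy group on this carbon would separate the hydrogen on the nitrogen from the methyl group and the nitrogen itself.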